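From Pyrrolidin-1-yl to Piperidin-1-yl: An Untested Step

The compounds below may be only part of what the source reports. "The series", "measured", "known", "first", "only" and "open" are said of these compounds alone.

Compound 1 `COc1cc2c(Oc3ccc(NC(=O)c4nn(-c5ccccc5)c(=O)c5ccccc45)cc3F)ccnc2cc1OCCCN1CCCC1` was measured in a functional assay on NCI-H460 cells (Homo sapiens) for cytotoxicity, read by MTT assay, with a stated time of 72 h (on this read-out higher numbers stand for weaker inhibition and lower numbers for stronger inhibition), where compound 1 gives 480 nM. Of the two numbers available it stands highest; the nearest is compound 2 `COc1cc2c(Oc3ccc(NC(=O)c4nn(-c5cccc(F)c5)c(=O)c5ccccc45)cc3F)ccnc2cc1OCCCN1CCCC1`, which in this assay gives 190 nM. For the measured compounds named here, the single measured step, a 2.5-fold lower number from compound 1 to compound 2 (0.40 log units; beyond the scatter), comes from fluoro in place of hydrogen on an aromatic carbon and leaves the ring on the saturated chain untouched.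

Compound 3 `COc1cc2c(Oc3ccc(NC(=O)c4nn(-c5ccccc5)c(=O)c5ccccc45)cc3F)ccnc2cc1OCCCN1CCCCC1` differs from compound 1 in one place: piperidin-1-yl in place of pyrrolidin-1-yl on a saturated chain carbon, three bonds along the chain from an oxygen on an aromatic ring. No measured pair alters this ring, so the step from compound 1 to compound 2 does not bear on the change, and nothing in the numbers shown says which way replacing a five-membered non-aromatic ring with a six-membered one moves the value in this assay. The account therefore expects for compound 3 a step of about a 1.1-fold lower number from compound 1 to compound 3 (0.03 log units; within the scatter), meaning no movement beyond the scatter. On that basis compound 3 is estimated in this assay at 450 nM, within a range from 200 nM to 1000 nM.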

Compound 3, half-maximal inhibitory concentration: 650 nM
Compound 3: middle estimate off by 1.4-fold (0.16 log units), on the low side; low and high end bracket the measured number.
By their numbers in this assay, from the lowest: compound 2; then compounds 1 and 3 (each within the scatter of the next).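

For the compounds shown here, this is the first measured change at the ring on the saturated chain: in this assay, piperidin-1-yl in place of pyrrolidin-1-yl gives a 1.4-fold higher number from compound 1 to compound 3 (0.13 log units; within the scatter). On this single pair, the position accepts the six-membered non-aromatic ring in place of the five-membered one with no shift that can be told from the scatter, whereas the fluoro replacement elsewhere on the molecule gave a 2.5-fold lower number from compound 1 to compound 2 (0.40 log units; beyond the scatter), a step beyond it. No measurement is available here that would link this result to any property of either ring.

The compounds shown leave open whether the step from hydrogen to fluoro seen on the core of compound 1 would carry over to compound 3, since only the pyrrolidin-1-yl member has been shown with that fluoro group. They also leave open how far this tolerance extends at the same place, as one pair says nothing about a morpholine ring, an open-chain dimethylamino group, a piperazine ring or a chain longer than 3-(piperidin-1-yl)propyl.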